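The source may hold more compounds than are shown below. What is called first, only, known or untested is meant among the compounds shown, and "the series" means these compounds.

Among the measured compounds shown here, compound 1 `CC(C)(C)Cc1c(-c2cc(F)ccc2F)sc(N)c1C(=O)c1ccc(Cl)cc1` is one of three compounds measured in an assay on CHO cells for displacement of a labelled ligand from adenosine receptor A3 (Homo sapiens), read by scintillation counting, tested at 10 uM; on this read-out lower numbers stand for less inhibition and higher numbers for more inhibition at the one concentration tested (going by the name of the read-out). In this assay compound 1 gives 1%, the lowest of the three numbers, although the gaps to the others lie within the usual scatter: compound 3 `CC(C)(C)Cc1c(-c2ccccc2)sc(N)c1C(=O)c1ccc(Cl)c(Cl)c1` gives 6% and compound 2 `CC(C)(C)Cc1csc(N)c1C(=O)c1ccc(Cl)c(Cl)c1` gives 10%. For the measured compounds named here, the only step between two measured compounds that differ in one place is a number 4 percentage points lower from compound 2 to compound 3 (within the scatter), a change within the scatter. Compound 4 `COc1ccc(-c2sc(N)c(C(=O)c3ccc(Cl)cc3)c2CC(C)(C)C)cc1` is not yet measured; it differs from compound 1 by 4-methoxyphenyl in place of 2,5-difluorophenyl on an aromatic carbon. Going by the values given here, no measured step swaps one aryl group for another, so the expectation rests on all three numbers sitting low and close together. Compound 4 is therefore expected to show a number 4 percentage points higher from compound 1 to compound 4 (within the scatter), with an estimate of 5% and a range from 0% to 15%.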

Compound 4, a percentage reported as inhibition, at one concentration (the size of the read-out at that concentration, not a potency): 2%
Compound 4: middle estimate off by 3 percentage points, on the high side; low and high end bracket the measured number.
By their numbers in this assay, from the lowest: compounds 1, 4, 3 and 2 (each within the scatter of the next).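

Among the compounds shown here, the step of a number 1 percentage points higher from compound 1 to compound 4 (within the scatter) in this assay is the first to swap one aryl group for another on the ring carbon next to the ring sulfur. The entering 4-methoxyphenyl adds a hydrogen-bond acceptor at an equal heavy-atom count, yet the two aryl groups cannot be told apart on this read-out. No supporting data bear on why the numbers stay so low. As far as these compounds go, it remains open whether a carboxylic acid or an aminomethyl group in place of the aryl group would give a number clear of the scatter.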